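The compounds below may be only part of what the source reports. "The series", "measured", "known", "first", "only" and "open" are said of these compounds alone.

Working notes on the series. Among the compounds with values here, in a functional assay on HT-29 cells (Homo sapiens) for inhibition, read by MTT assay, with a stated time of 48 h (a lower number here means a stronger inhibitor, a higher number a weaker inhibitor), compound 3, `COc1cc(-c2cc(-c3cccc4ccccc34)nc(-c3ccccc3)n2)cc(OC)c1OC`, gives 4730 nM, the only true number so far. Compound 1, `COc1ccc(-c2cc(-c3cc(OC)c(OC)c(OC)c3)nc(-c3ccccc3)n2)c(OC)c1`, gives > 25000 nM, which is a limit. Compound 2, `COc1cc(-c2cc(-c3cccc(O)c3)nc(-c3ccccc3)n2)cc(OC)c1OC`, gives > 25000 nM, also a limit. That shared ceiling is recorded as the limit of > 25000 nM in this assay, at which 2 of the 3 values shown sit.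

Compound 4, `COc1cc(-c2cc(-c3ccc(N)cc3)nc(-c3ccccc3)n2)cc(OC)c1OC`, carries 4-aminophenyl in place of naphthalen-1-yl on an aromatic carbon.

Within the data shown here, two measured steps bear on this change, both running towards naphthalen-1-yl: an at least 5.2-fold lower number from compound 1 to compound 3 (0.72 log units; beyond the scatter) and an at least 5.2-fold lower number from compound 2 to compound 3 (0.72 log units; beyond the scatter). As far as these compounds go, both are beyond the scatter, and their true sizes stay open. The step that the two limits leave unreadable from compound 1 to compound 2 adds nothing on size. Among the measured compounds shown here, no compound with 4-aminophenyl has been measured yet, so the reading rests on these two steps taken in reverse.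

Leaving naphthalen-1-yl for a single substituted phenyl is therefore expected to raise the number in this assay, with compound 2 at > 25000 nM as the closest guide. The expected change is a 2.5-fold higher number from compound 3 to compound 4 (0.40 log units; beyond the scatter), and a result reported only as a limit is quite possible. For compound 4 the estimated value is 12000 nM, with an expected range from 3000 nM to 25000 nM.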

Compound 4, half-maximal inhibitory concentration: > 25000 nM
Compound 4 was reported as a limit (the forecaster's own chance of this, stated with the estimate: 45%); at least 2.0-fold (0.31 log units) between middle value and limit.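

Replacing naphthalen-1-yl with 4-aminophenyl at this position gives an at least 5.2-fold higher number from compound 3 to compound 4 (0.72 log units; beyond the scatter), so a phenyl carrying an amino group joins 2,4-dimethoxyphenyl and 3-hydroxyphenyl in giving a higher number than naphthalen-1-yl, with no compound shown going against this. In this assay compound 4 gives > 25000 nM, which is a limit. Compound 3 therefore remains the only compound with a true number, and the steps among compound 1, compound 2 and compound 4 cannot be read: the limit of > 25000 nM in this assay, at which 3 of the 4 values shown sit.

As far as these compounds go, the true size of the step to compound 4 and any order among the three substituted phenyl compounds remain open. Also open, from the compounds shown here alone, is whether naphthalen-2-yl, quinolin-8-yl or an unsubstituted phenyl at this position would give a number in the range of compound 3 or reach the same limit.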